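The source may hold more compounds than are shown below. What is called first, only, known or untested is meant among the compounds shown, and "the series" means these compounds.

Compound 1 `CC(C)c1onc(-c2c(Cl)cccc2Cl)c1COc1ccc(-c2ccc3cc(C(=O)O)ncc3c2)cc1` — 120 nM
Compound 2 `CC(C)c1onc(-c2c(Cl)cccc2Cl)c1COc1ccc(-c2ccc3nc(C(=O)O)cnc3c2)cc1` — 150 nM
Compound 3 `CCc1cc(C(=O)O)nc2ccc(-c3ccc(OCc4c(-c5c(Cl)cccc5Cl)noc4C(C)C)cc3)cc12` — 75 nM

Three compounds share one core and differ only in the ring system that carries the carboxylic acid. In a functional assay for agonist activity at Bile acid receptor (Homo sapiens), read by FRET (a higher number here means that more compound is needed for the effect, a lower number that less compound is needed), compound 1 gives 120 nM and compound 2 gives 150 nM. Compound 3 gives 75 nM in this assay, the lowest of the three numbers; its gaps to compound 1 and to compound 2 both lie within the scatter of repeated measurements, so the three compounds cannot be told apart on these numbers.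

Compound 4 `CCOc1cc(C(=O)O)nc2ccc(-c3ccc(OCc4c(-c5c(Cl)cccc5Cl)noc4C(C)C)cc3)cc12` is the next step from compound 3. The change is ethoxy in place of ethyl on an aromatic carbon. For the measured compounds named here, no pair of measured compounds shows a change of this kind, so there is no measured step to lean on. Given that compounds 1 to 3 all land close together in this assay despite their different acid-bearing rings, the step from compound 3 to compound 4 is expected to stay within the scatter, a 1.1-fold higher number from compound 3 to compound 4 (0.03 log units; within the scatter). For compound 4 the estimate in this assay is 80 nM, with a range from 35 nM to 200 nM.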

Compound 4, half-maximal effective concentration: 52 nM
For compound 4 the middle estimate is 1.5-fold (0.19 log units) above the measured one; the range from low to high includes it.
By their numbers in this assay, from the lowest: compounds 4, 3, 1 and 2 (each within the scatter of the next, the first and the last beyond it).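

Compound 3 and compound 4 form the only pair shown that differs in one place, so this carbon opposite the ring nitrogen can now be read on its own. In this assay ethoxy in place of ethyl gives a 1.4-fold lower number from compound 3 to compound 4 (0.16 log units; within the scatter) at this position, so the swap, which brings in an oxygen and a hydrogen-bond acceptor, leaves the number within the scatter. Nothing measured bears on why the step is this small.

As far as these compounds go, only ethyl and ethoxy are seen at this carbon, so it remains open how a longer chain such as propoxy, an amine or a hydroxy group would read here. From the compounds shown here alone, it also remains open whether the same swap would give a similar step on the acid-bearing rings of compound 1 and compound 2.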